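The source may report more compounds than this note shows. Statements on the series, on what has been measured and on what is new or still open speak of the compounds shown alone.

Of the compounds shown here, two that share one core have been tested in a functional assay on CHO cells for agonist activity at Free fatty acid receptor 2 (Homo sapiens), read by cAMP accumulation (a lower number here means a stronger inhibitor, a higher number a weaker inhibitor), and a third awaits measurement. Compound 1 `CC(C)[C@H](C(=O)NC(C)(C)C)c1ccc(Cl)cc1` carries a tert-butyl group on its amide nitrogen. In this assay compound 1 gives > 100000 nM, which is a limit and not a measured number, so compound 1 stands only at that limit (the limit of > 100000 nM in this assay, at which 1 of the 2 values shown sits). Compound 2 `CC(C)[C@H](C(=O)Nc1nc2cc(Cl)ccc2o1)c1ccc(Cl)cc1` bears a ring system in place of that tert-butyl group, and in this assay compound 2 gives 4300 nM. Compound 3 `CC(C)[C@H](C(=O)Nc1ncc(C#N)s1)c1ccc(Cl)cc1` is the compound not yet measured; it differs from compound 1 in one place (5-cyano-1,3-thiazol-2-yl in place of tert-butyl on an amide-type nitrogen). Among the measured compounds shown here, no measured pair differs in exactly one place, so there is no measured step to lean on. Still, compound 2 at 4300 nM shows that an aromatic ring on this nitrogen can bring a number within reach of this assay, and the step of an at least 33-fold lower number from compound 1 to compound 3 (1.52 log units; beyond the scatter) is therefore expected to be a clear gain, well beyond the scatter. Compound 3 is expected to give 3000 nM, within a range of 800 nM to 15000 nM.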

Compound 3, half-maximal inhibitory concentration: 2000 nM
Compound 3: the middle estimate sits 1.5-fold (0.18 log units) above what was measured; low and high end bracket the measured number.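

In this assay, among the compounds shown here, the step of an at least 50-fold lower number from compound 1 to compound 3 (1.69 log units; beyond the scatter) is the first single change that can be read at this position, an amide-type nitrogen whose other neighbour is the carbonyl carbon. It shows that replacing the ringless tert-butyl with 5-cyano-1,3-thiazol-2-yl, which has one five-membered aromatic ring, is enough on its own to move the compound from the limit of the assay to a measured number. Compound 2 could only suggest this. It is not linked to compound 1 by a readable single change. Compound 1 stands only at a limit, so this step gives a minimum and the real size of the change stays unknown: the limit of > 100000 nM in this assay, at which 1 of the 3 values shown sits.

The compounds shown do not separate the contribution of the ring from that of the nitrile attached to it, so it remains open whether the same ring without the nitrile would give a similar number. As far as these compounds go, it also remains open how a carboxylic acid or an amine in place of the nitrile, or a plain phenyl ring on the amide nitrogen, would read in this assay.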